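Trading a Butyl Chain for a Cyclobutyl Ring

The source may hold more compounds than are shown below. What is called first, only, known or untested is meant among the compounds shown, and "the series" means these compounds.

Compound 1 `Nc1ncc(-c2ccc(O)c(Cl)c2)c(-c2ccccc2)n1`, compound 2 `CCCC(=O)Nc1ncc(-c2cccc(Cl)c2)c(-c2ccccc2)n1` and compound 3 `CCCCC(=O)Nc1ncc(-c2cccc(Cl)c2)c(-c2ccccc2)n1` share one core, and compound 4 `O=C(Nc1ncc(-c2cccc(Cl)c2)c(-c2ccccc2)n1)C1CCC1` keeps it too. In an assay on CHO cells for displacement of a labelled ligand from adenosine receptor A1 (Homo sapiens), read by scintillation counting, with a stated time of 1 h, tested at 1 uM (a higher number here means more inhibition at the concentration tested (going by the name of the read-out), a lower number less inhibition), compound 1 gives > 80%, which is a limit of the measurement rather than a number. Compound 2 also stands at a limit, > 80%. For the measured compounds named here, compound 3 is the one compound with a real number, giving 52%, so it stands below both of its neighbours. Going by the values given here, the measured step of a number at least 28 percentage points lower from compound 2 to compound 3 (beyond the scatter) is the only step on record, and because the limit of > 80% in this assay, at which 2 of the 3 values shown sit, hides the true value of compound 2, its full size is not known.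

Compound 4 differs from compound 3 in a single place: cyclobutyl in place of butyl on a carbonyl carbon. Among the compounds with values here, no measured step swaps a chain for a ring, so the step from compound 2 to compound 3 is the only guide; it shows that the size of the group on the carbonyl carbon can move the number, but a cyclobutyl keeps the same count of atoms as the butyl it replaces. The step is therefore expected to be a number 6 percentage points higher from compound 3 to compound 4 (within the scatter), not beyond the usual scatter. Compound 4 is expected to give about 58%, in the range 35% to 82%.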

Compound 4, a percentage reported as inhibition, at one concentration (the size of the read-out at that concentration, not a potency): 52%
Compound 4: middle estimate off by 6 percentage points, on the high side; measured number inside the range.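

At this carbonyl carbon, in this assay, a ring and an open chain with the same 4 carbon atoms cannot be told apart, with no change at the digits printed from compound 3 to compound 4 (within the scatter) as the whole of the swap from butyl to cyclobutyl. The lower reading seen with butyl is therefore not tied to an open chain, since the cyclobutyl group also gives a number at least 28 percentage points lower from compound 2 to compound 4 (beyond the scatter) when set against the propyl amide, and so both groups of 4 carbon atoms part from propyl in the same direction. On these data alone, the true size of that step remains unknown because compound 2 stands at a limit of the measurement rather than at a number: the limit of > 80% in this assay, at which 2 of the 4 values shown sit.

Two compounds with 4 carbon atoms and one with propyl cannot show whether the reading follows the carbon count or something else about these groups, and a cyclopropyl or a cyclopentyl on the same carbonyl carbon would bear on that question. A longer chain such as hexyl, or an amine at the end of the chain, also stands outside what these compounds can say about this position.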